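The compounds below may be only part of what the source reports. "The series", "measured", "known", "first", "only" and "open" are said of these compounds alone.

Compound 3 `CC(=O)OCC(C)(C)NC(=O)N(CCC1CCN(Cc2ccc(C)cc2)CC1)Cc1ccc(-c2ccc(F)cc2)cc1` gives 409 nM in an in vitro functional assay on HEK293 cells for antagonist activity at melanin-concentrating hormone receptor 1 (Homo sapiens), read by GTPgammaS binding, with a stated time of 45 min; a lower number here means a stronger inhibitor, a higher number a weaker inhibitor. Among the three numbers measured it stands second highest; compound 1 `Cc1ccc(CN2CCC(CCN(Cc3ccc(-c4ccc(F)cc4)cc3)C(=O)NC(C)C)CC2)cc1` gives 383 nM and compound 2 `COc1ccc(-c2ccc(CN(CCC3CCN(Cc4ccc(C)cc4)CC3)C(=O)NC(C)C)cc2)cc1` gives 467 nM in this assay, both within the scatter of compound 3. Compound 4 `CC(=O)OCC(C)(C)NC(=O)N(CCC1CCN(Cc2ccc(C)cc2)CC1)Cc1ccc(-c2ccccc2)cc1` differs from compound 3 by hydrogen in place of fluoro on an aromatic carbon. The step that bears on this edit is a 1.2-fold higher number from compound 1 to compound 2 (0.09 log units; within the scatter), also a change on an aromatic carbon, and it stayed within the scatter. The step of a 1.1-fold higher number from compound 1 to compound 3 (0.03 log units; within the scatter) touches another place and was likewise within the scatter. No step beyond the scatter is therefore expected in this assay. The expected step is a 1.1-fold higher number from compound 3 to compound 4 (0.04 log units; within the scatter). Compound 4 is estimated at 450 nM, with a range from 200 nM to 1000 nM.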

Compound 4, antagonist equilibrium constant: 366 nM
Beside the measured number, compound 4's estimate is 1.2-fold (0.09 log units) above it; low and high end bracket the measured number.
By their numbers in this assay, from the lowest: compounds 4, 1, 3 and 2 (each within the scatter of the next).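

Hydrogen in place of fluoro, which turns 4-fluorophenyl into phenyl, gives a 1.1-fold lower number from compound 3 to compound 4 (0.05 log units; within the scatter) in this assay, so in the presence of the acetoxymethyl group this position accepts loss of the fluoro without a step beyond the scatter. Together with a 1.2-fold higher number from compound 1 to compound 2 (0.09 log units; within the scatter), hydrogen, fluoro and methoxy on this aromatic carbon have so far produced no step beyond the scatter. No supporting data bear on this result. On these data alone, whether a carboxylic acid, an amine or a trifluoromethyl group here would move the number beyond the scatter remains open.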